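A few compounds are considered here, and "the series" means these few. Any claim that something is new, unique, unknown or untested is made for them only; others in the source may bear on it.

Measured so far:
compound 1 `Cc1ccc(Cn2cc(CSC(=S)N3CCN(C(=O)OCc4ccccc4)CC3)nn2)cc1` — 32600 nM
compound 2 `Fc1ccccc1Cn1cc(CSC(=S)N2CCNCC2)nn1` — > 128000 nM

Two compounds of the series have been run in a functional assay on ECa-109 cells (Homo sapiens) for inhibition, read by MTT assay, with a stated time of 72 h; on this read-out higher numbers stand for weaker inhibition and lower numbers for stronger inhibition. Compound 1 `Cc1ccc(Cn2cc(CSC(=S)N3CCN(C(=O)OCc4ccccc4)CC3)nn2)cc1` gives 32600 nM in this assay. Compound 2 `Fc1ccccc1Cn1cc(CSC(=S)N2CCNCC2)nn1` gives only a limit in this assay, > 128000 nM, which is not a number; compound 2 sits at the limit of > 128000 nM in this assay, at which 1 of the 2 values shown sits. For the measured compounds named here, compound 1 and compound 2 differ in more than one place, so no single step between them is counted.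

Compound 3 `Cc1ccc(Cn2cc(CSC(=S)N3CCNCC3)nn2)cc1` is not yet measured. It differs from compound 2 by 4-methylphenyl in place of 2-fluorophenyl on a saturated chain carbon bound to an aromatic nitrogen. Since compound 2 stands at a limit, the size of the step to compound 3 cannot be fixed from the data; the estimated step from compound 2 to compound 3 is an at least 1.2-fold lower number from compound 2 to compound 3 (0.10 log units; that floor lies within the scatter), a small gain not clearly beyond the scatter. For compound 3 the estimate in this assay is 100000 nM, expected between 30000 nM and 300000 nM, with a real chance that again only a limit is returned.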

Compound 3, half-maximal inhibitory concentration: > 128000 nM
Compound 3: a limit, no number; the forecaster's own chance of this, stated with the estimate: 55%; middle value at least 1.2-fold (0.10 log units) away from the limit.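

In this assay compound 3 returns only a limit, > 128000 nM, and this is a limit of the assay, not a number. The change of 4-methylphenyl for 2-fluorophenyl therefore cannot be read. The first single-place comparison that can be read lies on the amine nitrogen in the ring: with 4-methylphenyl held, hydrogen in place of benzyloxycarbonyl gives an at least 3.9-fold higher number from compound 1 to compound 3 (0.59 log units; beyond the scatter), so the benzyloxycarbonyl group is tied to the only number in the series so far, and the two compounds with hydrogen there share one limit: the limit of > 128000 nM in this assay, at which 2 of the 3 values shown sit.

From the compounds shown here alone, whether a smaller group on that nitrogen, such as acetyl or methoxycarbonyl, would still return a number remains open. Also open, going by these compounds, is whether 2-fluorophenyl and 4-methylphenyl would separate once benzyloxycarbonyl is present.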